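A few compounds are considered here, and "the series" means these few. Any claim that something is new, unique, unknown or untested is made for them only; others in the source may bear on it.

Measured compounds:

Compound 1, `COc1ccc2c(c1)[n+]([O-])c(C#N)c(-c1ccc(F)cc1)[n+]2[O-]`, gives 1.97 in a physicochemical assay for lipophilicity, measured as octanol-water partition; a lower number here means a more polar compound, a higher number a more lipophilic compound.
Compound 2, `COc1ccc2c(c1)[n+]([O-])c(C#N)c(-c1ccccc1)[n+]2[O-]`, gives 1.58 in this assay.
Compound 3, `COc1ccc(-c2c(C#N)[n+]([O-])c3ccccc3[n+]2[O-])cc1`, gives 1.58 in this assay.

Compound 2 and compound 1 differ in one place: fluoro in place of hydrogen on an aromatic carbon. This change made a step of a number 0.39 log units higher from compound 2 to compound 1 (beyond the scatter), so the fluorine-bearing compound 1 sits higher. Compound 3 has the same atoms as compound 2, joined differently; the difference between the two cores is not broken down here. Compound 3 and compound 2 stand level in this assay, and together they hold the lowest of the three numbers.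

Compound 4, `COc1ccc(-c2c(C#N)[n+]([O-])c3cc(F)ccc3[n+]2[O-])cc1`, has not yet been measured. It differs from compound 3 by fluoro in place of hydrogen on an aromatic carbon. Going by the values given here, this is the same kind of change as the one from compound 2 to compound 1, but the place is not the same: there the fluorine entered on a carbon para to a large group, here it enters on a carbon of a fused system of two rings, meta to a fused ring and para to a fused ring. Only one earlier example of this change exists among these compounds.

Among the compounds with values here, for compound 4 a step of a number 0.32 log units higher from compound 3 to compound 4 (beyond the scatter) in this assay is expected, resting on the single step of a number 0.39 log units higher from compound 2 to compound 1 (beyond the scatter) seen for the same kind of change, with a wider range because the place differs. Compound 4 is therefore estimated at 1.9, between 1.6 and 2.25.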

Compound 4, partition coefficient: 1.97
Beside the measured number, compound 4's estimate is 0.07 log units below it; the measured number falls inside the stated range.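

In this assay the fluoro change gave a number 0.39 log units higher from compound 3 to compound 4 (beyond the scatter) and the earlier example on the other core gave a number 0.39 log units higher from compound 2 to compound 1 (beyond the scatter) at a different place, so the two steps have the same size at the digits printed. For these two pairs, then, the change carried over from one core to the other with its size intact, but two pairs do not make a rule for other cores or for other aromatic carbons in the series. Nothing shown here explains why the two steps match, so the agreement stands as an observation only.

The compounds shown leave open whether fluoro would give a step of this size on the remaining aromatic carbons of these cores, and whether the match holds outside this assay as well. They also leave open how a different group at the same place would behave: a chlorine atom, a methyl group, an amine or a carboxylic acid might each give a step of quite another size, and only a further pair of compounds differing in that one place could tell.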